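Nitro to fluoro on the aryl ether series

A few compounds are considered here, and "the series" means these few. Any claim that something is new, unique, unknown or untested is made for them only; others in the source may bear on it.

Compound 1 `Fc1ccc(OCC2=NCCO2)cc1`, compound 2 `O=[N+]([O-])c1ccccc1OCC1=NCCO1` and compound 3 `O=[N+]([O-])c1ccc(OCC2=NCCO2)cc1` have been run in a toxicity assay on the whole organism with Rattus norvegicus as the target, at a dose of 100 mg/kg by the oral route; a higher number here means a stronger effect of the compound at the dose given, a lower number a weaker effect. Compound 1 gives 50%, compound 2 gives 20%, and compound 3 gives 10%. Compound 2 and compound 3 are built from the same atoms joined differently; the difference between their cores is not broken down here. From compound 3 to compound 1 the change is fluoro in place of nitro on an aromatic carbon, and it produced a number 40 percentage points higher from compound 3 to compound 1 (beyond the scatter). Compound 4 `Fc1ccccc1OCC1=NCCO1` is still to be measured. It differs from compound 2 by fluoro in place of nitro on an aromatic carbon, the same kind of change, the group here standing ortho to a group of 7 heavy atoms rather than para to a group of 7 heavy atoms. The change occurs twice in the set. The expected step is a number 30 percentage points higher from compound 2 to compound 4 (beyond the scatter), resting on a number 40 percentage points higher from compound 3 to compound 1 (beyond the scatter). Compound 4 is estimated at 50%, between 25% and 75%.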

Compound 4, a percentage reported as activity, at one dose (the size of the read-out at that dose, not a potency): 10%
Estimate against measurement, compound 4: 40 percentage points above; measured number below the stated range.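

Fluoro in place of nitro gave a number 10 percentage points lower from compound 2 to compound 4 (within the scatter) in this assay, so the change does not carry over as a single step from one core to the other: the same change on two cores in this assay, a number 40 percentage points higher (beyond the scatter) from compound 3 to compound 1 and a number 10 percentage points lower (within the scatter) from compound 2 to compound 4, 50 percentage points apart, beyond the scatter of two such steps

With one pair on each core, this shows that the step on one core cannot be used as an estimate for the other here. It does not show what separates the two cores, or which step a further core would follow.

Open, going by these compounds, is whether a chloro group, a methoxy group or an amine in place of nitro would follow either step. Also open, on these data alone, is whether a longer chain between the aromatic ring and the other ring would change the result.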